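The compounds below may be only part of what the source reports. "The series", "measured", "known", "first", "only" and "open" are said of these compounds alone.

Working notes on the series. Compound 1 `CO[C@H]1C(=O)N2C(C(=O)C(C)(C)C)=C(C)C(Sc3nnnn3C)S(=O)(=O)[C@H]12` and compound 2 `CO[C@H]1C(=O)N2C(C(=O)C(C)(C)C)=C(CSc3nnnn3C)C(Sc3nnnn3C)S(=O)(=O)[C@H]12` share one core; compound 3 `CO[C@H]1C(=O)N2C(C(=O)c3ccccc3)=C(C)CS(=O)(=O)[C@H]12` and compound 4 `CO[C@H]1C(=O)N2C(C(=O)c3ccccc3)=C(CSc3nnnn3C)CS(=O)(=O)[C@H]12` share another. The difference between the two cores is not broken down here. In a physicochemical assay for acid dissociation, compound 1 gives 7.9 and compound 2 gives 6; in this assay compound 3 gives 9.6, the highest number of the three measured.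

The change (1-methyl-1H-tetrazol-5-yl)sulfanyl in place of hydrogen on a saturated chain carbon bound to a double-bonded ring carbon brought a number 1.90 log units lower from compound 1 to compound 2 (beyond the scatter). The same change, ((1-methyl-1H-tetrazol-5-yl)sulfanyl in place of hydrogen on a saturated chain carbon bound to a double-bonded ring carbon), is made on the core of compound 3; the place described is the same word for word. Among the compounds with values here, from that single precedent the step is expected to be a number 1.70 log units lower from compound 3 to compound 4 (beyond the scatter), resting on compound 1 to compound 2 giving a number 1.90 log units lower from compound 1 to compound 2 (beyond the scatter); only one instance exists, so the size is uncertain. Compound 4 is therefore estimated at 7.9 in this assay, within 7.1 to 8.7.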

Compound 4, acid dissociation constant: 8.4
Compound 4: the middle estimate sits 0.50 log units below what was measured; the range from low to high includes it.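

In this assay the change gave a number 1.20 log units lower from compound 3 to compound 4 (beyond the scatter), and on the other core it gave a number 1.90 log units lower from compound 1 to compound 2 (beyond the scatter), so the direction carried from one core to the other. The sizes printed for the two steps differ, so one step does not fix the size of the other, and two cores alone establish no rule for the series. Nothing at hand bears on the reason for this result.

Open, on these data alone, is how a group such as a carboxylic acid or an amine, placed on a saturated chain carbon bound to a double-bonded ring carbon, would compare with (1-methyl-1H-tetrazol-5-yl)sulfanyl. Also open, as far as these compounds go, is whether the same direction would hold on a third core.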